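Cytotoxicity across the shared core: a hydroxy analogue

This account rests on a few compounds, and the source may have more. Where it says the series, first, only, none or still open, it means among the compounds named here.

Compound 1 `CC(=O)c1ccc(NC(=O)Nc2cc(C)nc3ccccc23)cc1` is tested in an ADME assay on HEK293 cells (Homo sapiens) for cytotoxicity, with a stated time of 72 h; a lower number here means that less compound is needed, a higher number that more compound is needed for the effect; the value for compound 1, > 25000 nM, is a limit of the assay and not a number. Compound 3 `CSc1ccccc1NC(=O)Nc1cc(C)nc2ccccc12` likewise returns only a limit in this assay, > 25000 nM. Compound 2 `COc1ccc(NC(=O)Nc2cc(C)nc3ccccc23)cc1Cl` gives 26000 nM in this assay, a numerical value sitting close to the limit of > 25000 nM in this assay, at which 2 of the 3 values shown sit. Compound 1 thus stands where most of the series stands, at the limit. Compound 4 `Cc1cc(NC(=O)Nc2ccc(O)cc2)c2ccccc2n1` differs from compound 1 by hydroxy in place of acetyl on an aromatic carbon. Within the data shown here, no measured pair isolates that change, so no step beyond the usual scatter is expected, and a limit again seems likely. The expected step is a step that the limit leaves unreadable from compound 1 to compound 4. Compound 4 is estimated at 30000 nM, from 12000 nM to 70000 nM.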

Compound 4, half-maximal effective concentration: > 25000 nM
Compound 4 was reported as a limit; the forecaster's own chance of this, stated with the estimate: 70%; the middle value lies beyond the limit too.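

Compound 1 and compound 4 both return only a limit, so no step can be read for hydroxy in place of acetyl: the limit of > 25000 nM in this assay, at which 3 of the 4 values shown sit.

The compounds shown leave open whether that change moves the value in this assay at all.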